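Methyl added to the pyridine ring of compound 3

A few compounds are considered here, and "the series" means these few. Any claim that something is new, unique, unknown or untested is made for them only; others in the source may bear on it.

compound 1 `Cc1cc(-c2ccccc2NCC2=NCCN2)on1` gives 95.5 nM
compound 2 `Cc1noc(-c2ccccc2NCC2=NCCN2)n1` gives < 5020 nM
compound 3 `c1ccc(-c2ccccc2NCC2=NCCN2)nc1` gives 30.2 nM

In a functional assay for activation of Alpha-1B adrenergic receptor (Homo sapiens), read by calcium flux (on this read-out lower numbers stand for an effect already at smaller amounts and higher numbers for an effect only at larger amounts of compound), compound 3 stands lowest of the two numbers available. Compound 1 sits higher, and a 3.2-fold lower number from compound 1 to compound 3 (0.50 log units; beyond the scatter) lies beyond the scatter. For compound 2 only a limit is reported, namely (the limit of < 5020 nM in this assay, at which 1 of the 3 values shown sits), so it is not a number. Because of that limit a step that the limit leaves unreadable from compound 1 to compound 2 and a step that the limit leaves unreadable from compound 2 to compound 3 cannot be read in size.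

Compound 4 `Cc1cccnc1-c1ccccc1NCC1=NCCN1` differs from compound 3 by methyl in place of hydrogen on an aromatic carbon. Going by the values given here, none of the measured steps bears directly on this change: each of them swaps one whole five- or six-membered ring for another, and none adds a methyl to a ring already present. The measured steps therefore give no direction, and the expected step of a 2.6-fold higher number from compound 3 to compound 4 (0.42 log units; beyond the scatter) is taken as small, possibly within the scatter, with a wide margin either way. Compound 4 is thus estimated at 80 nM, with a range from 20 nM to 400 nM.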

Compound 4, half-maximal effective concentration: < 100000 nM
Compound 4 gave a limit, no number (the forecaster's own chance of this, stated with the estimate: 5%); the middle value is on the limit's open side.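

In this assay compound 4 gives < 100000 nM, which is a limit and not a number, so the step from compound 3 to compound 4 cannot be read. The compounds shown leave open how far methyl in place of hydrogen moves the number, and in which direction.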